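Chloro for fluoro on the terminal aryl ring

The source may hold more compounds than are shown below. What is called first, only, known or untested is meant among the compounds shown, and "the series" means these compounds.

In an ADME assay on WI-38 cells (Homo sapiens) for cytotoxicity, read by MTT assay, with a stated time of 72 h (on this read-out higher numbers stand for weaker inhibition and lower numbers for stronger inhibition), compound 2 `CN(C)CCn1cnnc1-c1cc(Oc2ccc(NC(=O)N/N=C/c3ccc(F)cc3)cc2F)ccn1` gives 3980 nM, the highest of the two numbers in hand. Compound 1 `CN(C)CCn1cnnc1-c1cc(Oc2ccc(NC(=O)N/N=C/c3c[nH]c4ccccc34)cc2F)ccn1` stands nearest with 3620 nM; the step of a 1.1-fold higher number from compound 1 to compound 2 (0.04 log units; within the scatter) is within the scatter. Compound 3 `CN(C)CCn1cnnc1-c1cc(Oc2ccc(NC(=O)N/N=C/c3ccc(Cl)cc3)cc2F)ccn1` differs from compound 2 by chloro in place of fluoro on an aromatic carbon. Going by the values given here, no measured step bears directly on a chloro-for-fluoro exchange, and the only step available, a 1.1-fold higher number from compound 1 to compound 2 (0.04 log units; within the scatter), stayed within the scatter. Compound 3 is therefore expected to show no change beyond the scatter, a 1.0-fold higher number from compound 2 to compound 3 (0.00 log units; within the scatter). Compound 3 is estimated at 4000 nM, with a range from 2000 nM to 8000 nM.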

Compound 3, half-maximal inhibitory concentration: 1870 nM
The estimate for compound 3 lay 2.1-fold (0.33 log units) above the measured number; the measured number lies below the stated range.
By their numbers in this assay, from the lowest: compounds 3, 1 and 2 (each within the scatter of the next, the first and the last beyond it).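

In this assay, going by these compounds alone, this position on the terminal aryl ring responds to a single halogen exchange: chloro in place of fluoro gives a 2.1-fold lower number from compound 2 to compound 3 (0.33 log units; beyond the scatter), the only step beyond the scatter. With 4-chlorophenyl in place of 1H-indol-3-yl, the result is a 1.9-fold lower number from compound 1 to compound 3 (0.29 log units; within the scatter), so this change does not separate the two compounds. No supporting data on the cause of the chloro-for-fluoro shift are available.

On these data alone, whether the shift extends beyond these two halogens remains open. A bromo, methyl or methoxy group at this place on the ring would test that.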